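Cytotoxicity notes on a shared-core nucleoside-like series

A few compounds are considered here, and "the series" means these few. Any claim that something is new, unique, unknown or untested is made for them only; others in the source may bear on it.

Measured compounds:
compound 1 `Nc1nc(O)c2ncn(C[C@]3(CO)C[C@H]3CO)c2n1` — 240 ug/mL
compound 2 `O=c1[nH]c(=O)n(CC2(CO)CC2CO)cc1/C=C/Br` — a limit only, > 500 ug/mL
compound 3 `Cc1cn(CC2(CO)CC2CO)c(=O)[nH]c1=O` — a limit only, > 500 ug/mL

In a functional assay on Vero cells (Chlorocebus sabaeus) for cytotoxicity (a higher number here means that more compound is tolerated, a lower number that less compound is tolerated), compound 1 gives 240 ug/mL. For compound 2 the assay reports no number, only a limit, > 500 ug/mL. For compound 3 it likewise reports only a limit, > 500 ug/mL. Going by the values given here, the one measured step between neighbours, a step that the two limits leave unreadable from compound 2 to compound 3, therefore has no readable size. Compound 2 stands at the limit of > 500 ug/mL in this assay, at which 2 of the 3 values shown sit, so its standing on the numbers shown is a limit rather than a point.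

Compound 4 `O=c1[nH]c(=O)n(CC2(CO)CC2CO)cc1/C=C/Cl` is the next compound to be measured and differs from compound 2 by chloro in place of bromo on a double-bonded chain carbon bound to a double-bonded chain carbon. Among the compounds with values here, no measured step carries this change, and the only measured step, a step that the two limits leave unreadable from compound 2 to compound 3, is unreadable, so nothing in hand argues for a shift away from the limit. The expectation is that the step that the limit leaves unreadable from compound 2 to compound 4 shows no movement beyond the scatter. Compound 4 is accordingly estimated at 600 ug/mL, with a range from 300 ug/mL to 1500 ug/mL, and most likely reported again only as a limit.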

Compound 4, half-maximal cytotoxic concentration: > 500 ug/mL
Compound 4: a limit, no number; the forecaster's own chance of this, stated with the estimate: 80%; the middle value does not contradict the limit.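

In this assay compound 4 gives only a limit, > 500 ug/mL, so its steps from compound 2 and from compound 3 cannot be read. The compounds shown leave open whether chloro in place of bromo, or 2-chloroethenyl in place of methyl, changes the tolerated concentration at all.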